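This account rests on a few compounds, and the source may have more. Where it says the series, first, only, none or still open, it means among the compounds named here.

Compound 1 `O=C1CCC(CCN2CC(N3CCNCC3)C2)(c2ccc(Cl)c(Cl)c2)CN1Cc1ccccc1`: 5.01 nM
Compound 2 `CC(=O)N1CCN(C2CN(CCC3(c4ccc(Cl)c(Cl)c4)CCC(=O)N(Cc4ccccc4)C3)C2)CC1`: 1.59 nM
Compound 3 `CS(=O)(=O)N1CCN(C2CN(CCC3(c4ccc(Cl)c(Cl)c4)CCC(=O)N(CC4CC4)C3)C2)CC1`: 3.16 nM

In an assay on isolated protein (artery, Oryctolagus cuniculus) with Substance-P receptor (Homo sapiens) as the target (a lower number here means tighter binding, a higher number weaker binding), compound 3 is second highest of the three numbers, yet its gaps to compound 1 and to compound 2 both lie within the usual scatter, so the three compounds cannot be told apart with confidence. Among the measured compounds shown here, the one clean step among them, a 3.2-fold lower number from compound 1 to compound 2 (0.50 log units; beyond the scatter), is modest and concerns a substituent on the same distal ring that is now altered. Compound 4 `O=C1CCN(C2CN(CCC3(c4ccc(Cl)c(Cl)c4)CCC(=O)N(CC4CC4)C3)C2)CC1` arises from compound 3 by 4-oxopiperidin-1-yl in place of 4-(methylsulfonyl)piperazin-1-yl on a saturated ring carbon. For the measured compounds named here, no measured step swaps the whole ring, so the only guide is that a change on that distal ring has so far moved the number only modestly. Compound 4 is therefore expected to stay close to compound 3, with the step of a 1.3-fold higher number from compound 3 to compound 4 (0.10 log units; within the scatter) estimated to fall within the scatter. For compound 4 the expected value in this assay is 4 nM, with a range from 1.5 nM to 12 nM.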

Compound 4, dissociation constant: 1.26 nM
For compound 4 the middle estimate is 3.2-fold (0.50 log units) above the measured one, outside the stated range (below it).
By their numbers in this assay, from the lowest: compounds 4, 2, 3 and 1 (each within the scatter of the next, the first and the last beyond it).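

In this assay, 4-oxopiperidin-1-yl in place of 4-(methylsulfonyl)piperazin-1-yl on the saturated ring carbon gives a 2.5-fold lower number from compound 3 to compound 4 (0.40 log units; beyond the scatter). The earlier step, a 3.2-fold lower number from compound 1 to compound 2 (0.50 log units; beyond the scatter), changed only a substituent on the ring nitrogen and kept the ring itself, whereas this pair shows that the whole ring can be exchanged, with the methylsulfonyl group and one ring nitrogen gone, without weakening binding. No measurement here explains this gain.

As far as these compounds go, it remains open whether the ketone carbonyl of the new ring matters, which a plain piperidine or a morpholine at the same place would help to show. Among the compounds shown here, the exchange is also seen only with the cyclopropylmethyl group of compound 3 and compound 4, so its effect alongside a benzyl group remains unknown.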